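The compounds below may be only part of what the source reports. "The series", "measured", "known", "first", "only" and "open" are said of these compounds alone.

Measured compounds:
- Compound 1, `CCOC(=O)c1cccc(-c2ccc(OCC)cc2)c1`: 50000 nM
- Compound 2, `CCOc1ccc(-c2cccc(C(=O)OCCOC)c2)cc1`: 70000 nM
- Compound 3, `CCOc1ccc(-c2cccc(C(=O)N3CCCC3)c2)cc1`: 160000 nM

All three were tested in an assay on COS-7 cells for inhibition of patatin-like phospholipase domain-containing protein 2 (Mus musculus); a higher number here means a weaker inhibitor, a lower number a stronger inhibitor. Compound 3 has the highest number of the three; its nearest neighbour is compound 2, and compound 1 lies furthest from it. The two steps into compound 3 both raised the number: a 3.2-fold higher number from compound 1 to compound 3 (0.51 log units; beyond the scatter) and a 2.3-fold higher number from compound 2 to compound 3 (0.36 log units; beyond the scatter). The step between the two esters, a 1.4-fold higher number from compound 1 to compound 2 (0.15 log units; within the scatter), stayed within the scatter.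

Compound 4, `CCOc1ccc(-c2cccc([N+](=O)[O-])c2)cc1`, has not yet been measured in this assay. It differs from compound 3 in one place: nitro in place of (pyrrolidin-1-yl)carbonyl on an aromatic carbon. Within the data shown here, no measured step involves a nitro group, so the measured steps bear on this change only indirectly. They show that the (pyrrolidin-1-yl)carbonyl of compound 3 carries the highest number of the series, and that the two smaller groups on the same aromatic carbon in compound 1 and compound 2 gave lower numbers. On that basis a modest fall in the number is expected for compound 4, but with wide uncertainty, since nothing measured here resembles a nitro group. Compound 4 is therefore estimated to give 70000 nM in this assay, with a range from 20000 nM to 250000 nM, meaning an expected step of a 2.3-fold lower number from compound 3 to compound 4 (0.36 log units; beyond the scatter).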

Compound 4, half-maximal inhibitory concentration: > 200000 nM
Compound 4: no number, only a limit; the forecaster's own chance of this, stated with the estimate: 30%; middle value at least 2.8-fold (0.45 log units) away from the limit.
By their numbers in this assay, from the lowest: compounds 1 and 2 (each within the scatter of the next); then compound 3. At a limit, above all of these: compound 4.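

In this assay compound 4 stands at a limit of the assay and not at a number: the limit of > 200000 nM in this assay, at which 1 of the 4 values shown sits. Among these compounds, at this aromatic carbon, the change away from the carbonyl-linked groups of the earlier compounds did not lower the number, since the ester comparisons give an at least 2.8-fold higher number from compound 2 to compound 4 (0.45 log units; beyond the scatter) and an at least 4.0-fold higher number from compound 1 to compound 4 (0.60 log units; beyond the scatter), so nitro, with 3 heavy atoms, sits on the weak side of both esters. Against the amide the comparison gives only an at least 1.2-fold higher number from compound 3 to compound 4 (0.09 log units; that floor lies within the scatter), so this floor does not separate nitro from (pyrrolidin-1-yl)carbonyl, and the earlier trend among carbonyl groups, where the amide had the highest number, does not carry over to this smaller group.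

From the compounds shown here alone, how far compound 4 really lies beyond its limit stays unknown, and with it the true size of all three steps. Also open, going by these compounds, is whether any group on this aromatic carbon gives a clearly lower number than the esters, for example a carboxylic acid, a primary amine, a nitrile, or an ester with a longer chain.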